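Acetyl for cyano on the aryltriazene of compound 1

The source may hold more compounds than are shown below. What is called first, only, known or untested is meant among the compounds shown, and "the series" means these compounds.

Compound 1 `CN(/N=N/c1ccc(C#N)cc1)C(=O)CCc1ccc(O)cc1` is the reference point of this pair. Going by the values given here, in a physicochemical assay for pharmacokinetics, read by HPLC, in phosphate buffer, at pH 7.4 (a higher number here means that the compound lasts longer, a lower number that the compound disappears faster), compound 1 gives 86.4 h, the only plain number measured so far. Compound 2 `CN(/N=N/c1ccc(C#N)cc1)C(=O)NCCSc1ccc(O)cc1` is the second member; in this assay compound 2 reaches only a limit of the assay, > 240 h, so no number is known for it. Among the compounds with values here, the sole firm evidence is the limit of > 240 h in this assay, at which 1 of the 2 values shown sits, which says nothing about the step examined here.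

Compound 3 `CC(=O)c1ccc(/N=N/N(C)C(=O)CCc2ccc(O)cc2)cc1` differs from compound 1 in one place, (acetyl in place of cyano on an aromatic carbon). Within the data shown here, no measured step of this kind exists, so there is no basis for expecting a shift beyond the usual scatter in either direction. The step from compound 1 to compound 3 is therefore expected to be small, a 1.1-fold lower number from compound 1 to compound 3 (0.03 log units; within the scatter). For compound 3 the estimate in this assay is 80 h, with a range from 30 h to 220 h.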

Compound 3, half-life: 139 h
Beside the measured number, compound 3's estimate is 1.7-fold (0.24 log units) below it; measured number inside the range.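

The first step read at this position is acetyl in place of cyano on an aromatic carbon, para to a large group: in this assay it gives a 1.6-fold higher number from compound 1 to compound 3 (0.21 log units; within the scatter). The exchange of a triple-bonded group for a larger carbonyl-bearing one, with the hydrogen-bond acceptor count unchanged, therefore leaves the half-life within the scatter on the core of compound 1, and compound 3 gives a plain number rather than a limit. Nothing measured in the series bears on the cause of this step.

From the compounds shown here alone, whether an amine or a carboxylic acid at this aromatic carbon would also stay within the scatter remains open. Compound 2 gives only a limit of the assay, > 240 h, which offers no number against which the same exchange on its chain could be sized.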